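Moving a Bromine on the Phenoxy Tail

This account rests on a few compounds, and the source may have more. Where it says the series, first, only, none or still open, it means among the compounds named here.

Measured so far:
compound 1 `NC1=NC2(CCSCC2)N(OCCCOc2ccc(Br)cc2)C(N)=N1` — 20 nM
compound 2 `COc1ccc(OCCCON2C(N)=NC(N)=NC23CCOCC3)cc1` — 1500 nM

In a functional assay on HCT-116 cells (Homo sapiens) for antiproliferative activity, read by MTT assay, with a stated time of 72 h (on this read-out higher numbers stand for weaker inhibition and lower numbers for stronger inhibition), compound 1 gives 20 nM, the lower of the two numbers. Among the measured compounds shown here, compound 2 gives 1500 nM, a far higher number that lies beyond the scatter, though it differs from compound 1 in more than one place, so no single step is read from the pair. Compound 3 `NC1=NC2(CCSCC2)N(OCCCOc2cccc(Br)c2)C(N)=N1` differs from compound 1 by 3-bromophenyl in place of 4-bromophenyl on an oxygen on a saturated carbon. For the measured compounds named here, no measured pair shows how this change acts, so the step of a 2.0-fold higher number from compound 1 to compound 3 (0.30 log units; within the scatter) is expected to be small, a mild weakening at most. Compound 3 is expected to give 40 nM, within 10 nM to 160 nM.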

Compound 3, half-maximal inhibitory concentration: 1 nM
Beside the measured number, compound 3's estimate is 40-fold (1.60 log units) above it; measured number outside the range, below it.
By their numbers in this assay, from the lowest: compound 3; then compound 1; then compound 2.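

Swapping 4-bromophenyl for 3-bromophenyl keeps the same atoms, yet in this assay it gives a 20-fold lower number from compound 1 to compound 3 (1.30 log units; beyond the scatter). The phenoxy tail is therefore sensitive to where its bromine sits, and here the 3-bromophenyl group gives the stronger inhibition. Nothing available explains this gain. The compounds shown leave open whether chlorine or a nitrile in place of the bromine would keep this strength. They also leave open whether a longer chain between the oxygens would keep it.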